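The source may hold more compounds than are shown below. What is called first, only, known or untested is meant among the compounds shown, and "the series" means these compounds.

Series notes. Compound 1 `Cc1cncc(-c2noc([C@H](C)NC(=O)c3cc(C(F)(F)F)nn3C)n2)c1` and compound 2 `C[C@H](NC(=O)c1cc(C(F)(F)F)nn1C)c1nc(-c2ccnc(N3CCCC3)c2)no1` are the measured pair. In an assay on T-REx-293 cells for inhibition of potassium channel subfamily T member 1 (Homo sapiens), read by patch clamp (on this read-out higher numbers stand for weaker inhibition and lower numbers for stronger inhibition), compound 1 gives 1370 nM. In this assay compound 2 gives 573 nM, the lower of the two numbers, and its gap to compound 1 lies beyond the scatter. Compound 3 `C[C@H](NC(=O)c1cc(C(F)(F)F)nn1C)c1nc(-c2ccnc(C(F)(F)F)c2)no1` carries trifluoromethyl in place of pyrrolidin-1-yl on an aromatic carbon. For the measured compounds named here, no measured pair shows this change, so the size of the step is open. Compound 3 is expected to come out somewhat weaker, with the step of a 1.7-fold higher number from compound 2 to compound 3 (0.24 log units; within the scatter) estimated at about the edge of the scatter. The estimate for compound 3 in this assay is 1000 nM, within 300 nM to 3500 nM.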

Compound 3, half-maximal inhibitory concentration: 40 nM
Compound 3: middle estimate off by 25-fold (1.40 log units), on the high side, and the stated range ends above it.
By their numbers in this assay, from the lowest: compound 3; then compound 2; then compound 1.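

In this assay, trifluoromethyl in place of pyrrolidin-1-yl on the aromatic carbon next to the ring nitrogen gives a 14-fold lower number from compound 2 to compound 3 (1.16 log units; beyond the scatter), so this position is highly sensitive to the group it carries. Replacing 5-methylpyridin-3-yl with 2-(trifluoromethyl)pyridin-4-yl gives a 34-fold lower number from compound 1 to compound 3 (1.53 log units; beyond the scatter), which leaves compound 3 as the strongest inhibitor of the three. Nothing available accounts for the size of these steps. As far as these compounds go, how a chlorine atom or a nitrile on this carbon would compare with trifluoromethyl remains open. Whether the gain would persist with a different amide portion is also unresolved.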